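An Estimate for Compound 4 from Three Limit Values

A few compounds are considered here, and "the series" means these few. Any claim that something is new, unique, unknown or untested is made for them only; others in the source may bear on it.

Measured so far:
- Compound 1, `O=S(=O)(O)c1ccc(/N=N/c2c(O)ccc3ccccc23)c2ccccc12`: < 5%
- Compound 2, `Oc1ccc2ccccc2c1/N=N/c1c(O)ccc2ccccc12`: < 5%
- Compound 3, `Cc1[nH]n(C(C)(C)C)c(=O)c1/N=N/c1c(O)cc(S(=O)(=O)O)c2ccccc12`: < 5%

All three entries come from an assay on BaF3 cells with thrombopoietin receptor (Homo sapiens) as the target, read by a luciferase reporter; a higher number here means a larger maximal response, a lower number a smaller maximal response. For compound 1 the value is a limit of the assay, not a measured number. The same holds for compound 2, whose entry is also a limit. Compound 3 likewise sits at a limit, and its standing among the numbers shown is summed up by the limit of < 5% in this assay, at which 3 of the 3 values shown sit. Among the measured compounds shown here, no step between two measured compounds is available, so nothing here shows how a change in structure moves the maximal response.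

Compound 4, `Cc1[nH]n(-c2ccc(C(C)(C)C)cc2)c(=O)c1/N=N/c1c(O)cc(S(=O)(=O)O)c2ccccc12`, has not yet been measured in this assay. It differs from compound 3 in a single place: 4-(tert-butyl)phenyl in place of tert-butyl on an aromatic nitrogen. With every measured compound at the same limit, the most cautious reading is that this change moves the maximal response little if at all, and a small rise is the only direction that the data leave room to notice. The step from compound 3 to compound 4 is therefore expected to be a number at least 1 percentage points higher from compound 3 to compound 4 (that floor lies within the scatter). Compound 4 is expected to give 6%, with a range from 0% to 20%.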

Compound 4, largest response reached (reported as efficacy), in percent of the reference or control that the assay uses: 86%
Beside the measured number, compound 4's estimate is 80 percentage points below it; the whole stated range lies below it.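

Among the compounds shown here, this aromatic nitrogen is the first place where a single change is seen to matter: in this assay, 4-(tert-butyl)phenyl in place of tert-butyl gives a number at least 81 percentage points higher from compound 3 to compound 4 (beyond the scatter). The earlier compounds shown here could not show this, as none of them rose off the floor of the assay and no pair among them differed in one place, so they gave no sign that this type of compound could produce a large response at all: the limit of < 5% in this assay, at which 3 of the 4 values shown sit. The entering group still holds a tert-butyl and adds one six-membered aromatic ring of carbon only, so in this one pair the large rise goes with adding that ring between the nitrogen and the tert-butyl, not with swapping the tert-butyl for something else.

A single pair cannot say whether the ring alone is enough, which a plain phenyl on that nitrogen would test, or whether the tert-butyl on the ring also takes part. It also leaves open how the response would change if a carboxylic acid, an amine or a longer chain stood on the ring in place of the tert-butyl.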